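The source may report more compounds than this note shows. Statements on the series, on what has been measured and on what is new or still open speak of the compounds shown alone.

Values measured in an ADME assay on the whole organism (Rattus norvegicus) for pharmacokinetics, at a dose of 1 mg/kg by the intravenous route; a lower number here means that more of the compound stays in the plasma, a higher number that more of the compound sits outside the plasma:
- Compound 1 `Cc1c(-c2ccc3c(c2)OCCO3)cccc1C(F)(F)Oc1cc(OCc2cncc(C#N)c2)c(CNC(CO)(CO)CO)cc1Cl`: 4.18 L/kg
- Compound 2 `Cc1c(-c2ccc3c(c2)OCCO3)cccc1C(F)(F)Oc1cc(OCc2ccnc(C#N)c2)c(CN2CCCC[C@H]2C(=O)O)cc1Cl`: 5.31 L/kg
- Compound 3 `Cc1c(-c2ccc3c(c2)OCCO3)cccc1C(F)(F)Oc1cc(OCc2ccnc(C#N)c2)c(CN[C@@H]2C(O)O[C@H](CO)[C@@H](O)[C@@H]2O)cc1Cl`: 3.92 L/kg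

Compound 3, at 3.92 L/kg, lies within the usual scatter of both other compounds, so the three numbers cannot be firmly ranked. Compound 4 `Cc1c(-c2ccc3c(c2)OCCO3)cccc1C(F)(F)Oc1cc(OCc2ccnc(C#N)c2)c(CN[C@@H](CO)[C@@H](O)[C@@H](O)[C@H](O)CO)cc1Cl` differs from compound 3 in one place: a group of 11 heavy atoms (6 carbon, 5 oxygen; no ring) in place of a group of 11 heavy atoms (6 carbon, 5 oxygen; one six-membered non-aromatic ring with 1 hetero atom), on an amine nitrogen. Among the compounds with values here, no measured step shows what opening this ring does. The nearest guide is a 1.4-fold lower number from compound 2 to compound 3 (0.13 log units; within the scatter), which also swaps one group carrying a six-membered non-aromatic ring for another and stays within the scatter. No shift beyond the scatter is therefore expected in this assay. The expected step is a 1.0-fold higher number from compound 3 to compound 4 (0.01 log units; within the scatter). For compound 4 the estimate is 4 L/kg, with an expected range from 2.5 L/kg to 6.3 L/kg.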

Compound 4, volume of distribution at steady state: 18 L/kg
The estimate for compound 4 lay 4.5-fold (0.65 log units) below the measured number; the measured number lies above the stated range.
By their numbers in this assay, from the lowest: compounds 3, 1 and 2 (each within the scatter of the next); then compound 4.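

In this assay this position proves sensitive to whether the group on the amine nitrogen is a ring or a chain: the same heavy atoms, with the six-membered non-aromatic ring opened, give a 4.6-fold higher number from compound 3 to compound 4 (0.66 log units; beyond the scatter) with no change in net charge. The open chain also stands apart from the ring carrying a carboxylic acid, with a 3.4-fold higher number from compound 2 to compound 4 (0.53 log units; beyond the scatter) as the step. No measurement shown here explains this rise.

Still open, from the compounds shown here alone, is whether a shorter open chain with fewer hydroxyl groups, or an open chain ending in a carboxylic acid, would keep the higher number.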